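Chloro to fluoro on the hydroxy compound

The source may hold more compounds than are shown below. What is called first, only, known or untested is meant among the compounds shown, and "the series" means these compounds.

So far two compounds carry numbers in a functional assay on SNO cells (Homo sapiens) for cytotoxicity, read by XTT assay, with a stated time of 24 h; a higher number here means a weaker inhibitor, a lower number a stronger inhibitor. Compound 1 (`CC(=O)Oc1cc(C)c(Cl)c2c1C(=O)C=CC2=O`) gives 28800 nM. Compound 2 (`Cc1cc(O)c2c(c1Cl)C(=O)C=CC2=O`) gives 17200 nM, which lies within the scatter of the value for compound 1, so the two cannot be ranked.

Next is compound 3 (`Cc1cc(O)c2c(c1F)C(=O)C=CC2=O`), which differs from compound 2 as follows: fluoro in place of chloro on an aromatic carbon. This is fluoro in place of chloro on an aromatic carbon, ortho to a methyl group and para to a hydroxy group.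

Going by the values given here, the only measured step is a 1.7-fold lower number from compound 1 to compound 2 (0.22 log units; within the scatter). Among the compounds with values here, it lies within the scatter and concerns hydrogen in place of acetyl, so no measured step gives a size for this exchange. From the compounds shown here alone, no change beyond the scatter is expected, and the direction stays open.

The expected step is a 1.2-fold higher number from compound 2 to compound 3 (0.07 log units; within the scatter). Compound 3 is estimated at 20000 nM, with an expected range of 8000 nM to 48000 nM.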

Compound 3, half-maximal inhibitory concentration: 18900 nM
For compound 3 the middle estimate is 1.1-fold (0.02 log units) above the measured one; the range from low to high includes it.
By their numbers in this assay, from the lowest: compounds 2, 3 and 1 (each within the scatter of the next).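

In this assay, fluoro in place of chloro on the aromatic carbon ortho to a methyl group and para to a hydroxy group gives a 1.1-fold higher number from compound 2 to compound 3 (0.04 log units; within the scatter) and so compound 2 and compound 3 cannot be ranked. Going by these compounds alone, this is the first measured exchange at this position, and it shows that, with the hydroxy group in place, either halogen gives a value within the scatter of the other. No measured evidence bears on the reading of this result.

From the compounds shown here alone, whether the position tolerates any group is still open, since chloro and fluoro are single-atom groups and say nothing about an amine, a methoxy group or a longer chain there. Also open is whether fluoro would read the same on the acetyl compound, as the only fluoro compound shown carries the hydroxy group.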